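This account rests on a few compounds, and the source may have more. Where it says the series, first, only, none or still open, it means among the compounds named here.

Measured compounds:
- compound 1, `Cc1cnn(C(=O)N(C)CCN(C)C(c2ccc(OCc3ccccc3)cc2)c2ccc(OCc3ccccc3)cc2)c1`, in an assay on membranes from brain for binding affinity to Fatty-acid amide hydrolase 1 (Mus musculus), read by fluorescence, with stated times of 1 h and 30 min (on this read-out lower numbers stand for stronger inhibition and higher numbers for weaker inhibition), gives > 1000000 nM, which is a limit of the assay and not a number.
- compound 2, `CN(CCN(C)C(c1ccc(OCc2ccccc2)cc1)c1ccc(OCc2ccccc2)cc1)C(=O)n1cccn1`, in this assay gives > 1000000 nM, again only a limit.
- compound 3, `Cc1cnn(C(=O)N2CCN(C(c3ccc(OCc4ccccc4)cc3)c3ccc(OCc4ccccc4)cc3)CC2)c1`, in this assay gives > 100000 nM, also a limit.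

Compound 1 and compound 2 share one core, an open chain carrying two nitrogen atoms. Compound 3 is built on a different core, and the difference between the two cores is not broken down here. The change from compound 1 to compound 2 is hydrogen in place of methyl on an aromatic carbon. Its size is a step that the two limits leave unreadable from compound 1 to compound 2; the step cannot be read because the limit of > 1000000 nM in this assay, at which 2 of the 3 values shown sit, is where both values sit, so the change may have done anything from nothing to a great deal without the assay showing it.

Compound 4, `O=C(N1CCN(C(c2ccc(OCc3ccccc3)cc2)c2ccc(OCc3ccccc3)cc2)CC1)n1cccn1`, has not yet been measured. It differs from compound 3 by hydrogen in place of methyl on an aromatic carbon. The place of this change is described in the same words as for the pair of compound 1 and compound 2, so it is the same change made on the other core.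

For compound 3 the value sits at the limit of > 100000 nM in this assay, at which 1 of the 3 values shown sits. Nothing among the three measured compounds shows the change from a methyl to a hydrogen on the pyrazole moving a value into readable territory. The expected step that the limit leaves unreadable from compound 3 to compound 4 is therefore one of no readable change, and compound 4 is expected most likely to remain at a limit. For compound 4 the estimated value is 500000 nM, with an expected span from 100000 nM to 5000000 nM.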

Compound 4, half-maximal inhibitory concentration: > 100000 nM
Compound 4 ended at the assay's limit; the forecaster's own chance of this, stated with the estimate: 85%; the middle value is on the limit's open side.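

In this assay compound 4 gives > 100000 nM, which is a limit of the assay and not a number. Compound 3 also sits at a limit, so no size can be read for the step between compound 3 and compound 4. The compounds shown leave open how strongly any of the four acts in this assay, and whether replacing methyl with hydrogen has any effect on either core.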